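Removing the chain hydroxy from compound 2

This account rests on a few compounds, and the source may have more. Where it says the series, first, only, none or still open, it means among the compounds named here.

Going by the values given here, compound 2 `Cn1ncc(Cl)c1-c1cc(C(=O)N[C@@H]2CN[C@H](CCCO)C[C@H]2c2ccc(Cl)c(Cl)c2)oc1Cl` stands second highest of the three numbers known in an assay for inhibition of RAC-alpha serine/threonine-protein kinase (Homo sapiens), read by HTRF, with a stated time of 1 h (on this read-out lower numbers stand for stronger inhibition and higher numbers for weaker inhibition), where compound 2 gives 2.56 nM. Compound 1 `Cn1ncc(Cl)c1-c1cc(C(=O)N[C@@H]2CN[C@H](CCNS(C)(=O)=O)C[C@H]2c2ccc(F)c(F)c2)oc1Cl` gives 3.29 nM in this assay, and compound 3 `CNC(=O)C[C@@H]1C[C@@H](c2ccc(F)c(F)c2)[C@H](NC(=O)c2cc(-c3c(Cl)cnn3C)c(Cl)o2)CN1` gives 1.37 nM in this assay; both gaps to compound 2 lie within the scatter, so no order among these three is claimed. Compound 4 `CCC[C@@H]1C[C@@H](c2ccc(Cl)c(Cl)c2)[C@H](NC(=O)c2cc(-c3c(Cl)cnn3C)c(Cl)o2)CN1` differs from compound 2 by hydrogen in place of hydroxy on a saturated chain carbon, three bonds along the chain from a saturated ring carbon, so that 3-hydroxypropyl becomes propyl. Among the compounds with values here, the only step measured in one place, a 2.4-fold lower number from compound 1 to compound 3 (0.38 log units; beyond the scatter), exchanges one chain-end group for another rather than removing one, and it is modest. Within the data shown here, no measured step in this set removes a hydroxy from the chain, so the present change has no direct precedent here. The change from compound 2 to compound 4 is therefore expected to give a step of a 1.6-fold higher number from compound 2 to compound 4 (0.19 log units; within the scatter) in this assay, not beyond the scatter, if anything toward a higher number. Compound 4 is estimated at 4 nM in this assay, with a range from 1.5 nM to 12 nM.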

Compound 4, half-maximal inhibitory concentration: 10.4 nM
Estimate against measurement, compound 4: 2.6-fold (0.41 log units) below; the measured number falls inside the stated range.
By their numbers in this assay, from the lowest: compounds 3, 2 and 1 (each within the scatter of the next, the first and the last beyond it); then compound 4.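

Going by these compounds alone, the step of a 4.1-fold higher number from compound 2 to compound 4 (0.61 log units; beyond the scatter) in this assay is the first reading in this set of what a single chain-end group contributes, as opposed to what follows when one chain-end group is exchanged for another. At this place, on a saturated chain carbon, three bonds along the chain from a saturated ring carbon, the hydroxy is therefore not a neutral passenger: going from 3-hydroxypropyl to propyl moves the number beyond the scatter. The step is still modest, and compound 4 gives 10.4 nM with no hydroxy on the chain, so inhibition in this series does not depend on that group. Nothing in the data explains the size or direction of this step.

From the compounds shown here alone, whether the gain belongs to the hydroxy itself or to any group at the chain end stays open, since a methoxy, a primary amine or a carboxylic acid on the same propyl chain would separate these readings. Going by these compounds, it is also open whether the step holds for a shorter chain such as 2-hydroxyethyl, or with the fluorine-bearing aryl group of compound 1 and compound 3.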